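Trifluoromethyl to Nitro: An Untested Aryl Swap

A few compounds are considered here, and "the series" means these few. Any claim that something is new, unique, unknown or untested is made for them only; others in the source may bear on it.

Compound 1 `CC1=CCCC(C)(C)C1/C=C/C(=O)/C=C/c1cccc(C(F)(F)F)c1`: 1000 nM
Compound 2 `CC1=CCCC(C)(C)C1/C=C/C(=O)/C=C/c1cc(C(F)(F)F)ccc1F`: 1700 nM

In a functional assay on LNCaP cells (Homo sapiens) for cytotoxicity, read by MTT assay, with a stated time of 72 h (a higher number here means a weaker inhibitor, a lower number a stronger inhibitor), compound 1 gives 1000 nM, the lower of the two numbers, while compound 2 gives 1700 nM; the gap between them lies within the scatter. Within the data shown here, the only measured step, a 1.7-fold higher number from compound 1 to compound 2 (0.23 log units; within the scatter), adds a fluorine and leaves the trifluoromethyl in place, so it bears only loosely on compound 3 `CC1=CCCC(C)(C)C1/C=C/C(=O)/C=C/c1cccc([N+](=O)[O-])c1`, where the change is nitro in place of trifluoromethyl on an aromatic carbon. Among the measured compounds shown here, no measured pair tests this swap, so no shift beyond the scatter in this assay is expected. Compound 3 is estimated at 1000 nM, between 400 nM and 2500 nM. The expected step is no change at the digits printed from compound 1 to compound 3 (within the scatter).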

Compound 3, half-maximal inhibitory concentration: 3300 nM
For compound 3 the middle estimate is 3.3-fold (0.52 log units) below the measured one, outside the stated range (above it).
By their numbers in this assay, from the lowest: compounds 1, 2 and 3 (each within the scatter of the next, the first and the last beyond it).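

In this assay nitro in place of trifluoromethyl on an aromatic carbon gives a 3.3-fold higher number from compound 1 to compound 3 (0.52 log units; beyond the scatter) and this is the only step shown that lies beyond the scatter. This position therefore responds to the group it carries, and of these two groups trifluoromethyl gives the lower number, meaning the stronger inhibitor. Nothing measured here explains the difference.

On these data alone, how other groups at this aromatic carbon, such as a nitrile or a carboxylic acid, would read remains open. Also open, as far as these compounds go, is whether the same swap would give a similar step with the fluoro of compound 2 present.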